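Hydroxy to methanesulfonamido on the chain of compound 2

This account rests on a few compounds, and the source may have more. Where it says the series, first, only, none or still open, it means among the compounds named here.

The series shares the core of compound 1 `Cn1ncc(Cl)c1-c1cc(C(=O)N[C@@H]2CNCC[C@H]2c2ccc(C(F)(F)F)cc2)oc1Cl`, which in an assay for inhibition of RAC-alpha serine/threonine-protein kinase (Homo sapiens), read by HTRF, with a stated time of 1 h (on this read-out lower numbers stand for stronger inhibition and higher numbers for weaker inhibition), gives 9.3 nM. For the measured compounds named here, compound 2 `Cn1ncc(Cl)c1-c1cc(C(=O)N[C@@H]2CN[C@H](CCO)C[C@H]2c2ccc(F)c(F)c2)oc1Cl` adds a 2-hydroxyethyl chain and a 3,4-difluorophenyl group; in this assay compound 2 gives 0.98 nM, the lowest of the three numbers measured so far, with both other compounds lying beyond the scatter from it. Going by the values given here, compound 3 `Cn1ncc(Cl)c1-c1cc(C(=O)N[C@@H]2CN[C@H](CCO)C[C@H]2c2ccc(Cl)c(Cl)c2)oc1Cl` carries 3,4-dichlorophenyl instead, and in this assay compound 3 gives 2.74 nM; the only single-point step within the measured set is a 2.8-fold higher number from compound 2 to compound 3 (0.45 log units; beyond the scatter). Compound 2 is thus the closest reference for compound 4 `Cn1ncc(Cl)c1-c1cc(C(=O)N[C@@H]2CN[C@H](CCNS(C)(=O)=O)C[C@H]2c2ccc(F)c(F)c2)oc1Cl`, which differs from it in one place: methanesulfonamido in place of hydroxy on a saturated chain carbon, two bonds along the chain from a saturated ring carbon. Among the compounds with values here, no measured step touches the chain end; the one step available concerns the aryl group and is modest. The measured set offers nothing that argues for a change beyond the scatter at this position, and a small shift in either direction is equally plausible. Compound 4 is estimated at 1.5 nM in this assay, with a range of 0.5 nM to 5 nM. The step this estimate means is expected to be a 1.5-fold higher number from compound 2 to compound 4 (0.18 log units; within the scatter), within the scatter.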

Compound 4, half-maximal inhibitory concentration: 3.29 nM
Compound 4: the middle estimate sits 2.2-fold (0.34 log units) below what was measured; low and high end bracket the measured number.
By their numbers in this assay, from the lowest: compound 2; then compounds 3 and 4 (each within the scatter of the next); then compound 1.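

In this assay the chain end now has a step of its own: methanesulfonamido in place of hydroxy on a saturated chain carbon, two bonds along the chain from a saturated ring carbon, gives a 3.4-fold higher number from compound 2 to compound 4 (0.53 log units; beyond the scatter). For the compounds shown here, this position therefore responds to the change, though modestly, and the step at the chain end joins the one on the aryl group, a 2.8-fold higher number from compound 2 to compound 3 (0.45 log units; beyond the scatter), which is also modest, so neither site has yet produced a large step from compound 2. No measurement at hand bears on the origin of the step at the chain end.

Open, as far as these compounds go, is how other ends on the same 2-hydroxyethyl position would read against compound 2, for instance a primary amine, a carboxylic acid, an acetamide, or a longer chain ending in hydroxy, and such groups would show whether the step follows the loss of hydroxy or the entry of the sulfonyl part. Also open, from the compounds shown here alone, is whether the same exchange gives a step of similar size when the aryl group is 3,4-dichlorophenyl, as in compound 3.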